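The source may hold more compounds than are shown below. What is called first, only, known or untested is meant among the compounds shown, and "the series" means these compounds.

Compound 1 `CCN1CCN(c2cc(C)c3cc(NC(=O)c4cccc(Br)c4)ccc3n2)CC1`: 11600 nM
Compound 2 `CCN1CCN(c2cc(C)c3cc(NC(=O)c4ccccc4Cl)ccc3n2)CC1`: > 50000 nM
Compound 3 `CCN1CCN(c2cc(C)c3cc(NC(=O)c4ccc(Cl)c(Cl)c4)ccc3n2)CC1`: 1380 nM

In a functional assay on MCF7 cells (Homo sapiens) for antiproliferative activity, read by MTT assay, with a stated time of 72 h (a lower number here means a stronger inhibitor, a higher number a weaker inhibitor), compound 3 gives 1380 nM, the lowest of the two numbers shown. Compound 1 sits higher, with an 8.4-fold lower number from compound 1 to compound 3 (0.92 log units; beyond the scatter). For compound 2 the value of > 50000 nM is only a limit of the assay, not a number, as the limit of > 50000 nM in this assay, at which 1 of the 3 values shown sits, records. Compound 4 `CCN1CCN(c2cc(C)c3cc(NC(=O)c4ccc(Br)cc4)ccc3n2)CC1` differs from compound 3 by 4-bromophenyl in place of 3,4-dichlorophenyl on a carbonyl carbon. Every measured step here changes the halogenated phenyl on the carbonyl carbon, and each was beyond the scatter: an at least 4.3-fold higher number from compound 1 to compound 2 (0.63 log units; beyond the scatter), an 8.4-fold lower number from compound 1 to compound 3 (0.92 log units; beyond the scatter) and an at least 36-fold lower number from compound 2 to compound 3 (1.55 log units; beyond the scatter). A single bromine in place of two chlorines is expected to weaken inhibition, so compound 4 is expected to show a 5.8-fold higher number from compound 3 to compound 4 (0.76 log units; beyond the scatter) in this assay. Compound 4 is estimated at 8000 nM, in the range 2000 nM to 30000 nM.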

Compound 4, half-maximal inhibitory concentration: 5940 nM
Compound 4: the middle estimate sits 1.3-fold (0.13 log units) above what was measured; the range from low to high includes it.
By their numbers in this assay, from the lowest: compound 3; then compounds 4 and 1 (each within the scatter of the next). At a limit, above all of these: compound 2.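

Exchanging 3-bromophenyl for 4-bromophenyl gives a 2.0-fold lower number from compound 1 to compound 4 (0.29 log units; within the scatter) and so does not separate these two single-bromine groups on the carbonyl carbon, while 3,4-dichlorophenyl stays clearly ahead of 4-bromophenyl, with a 4.3-fold higher number from compound 3 to compound 4 (0.63 log units; beyond the scatter) as the step. Set against 2-chlorophenyl, 4-bromophenyl gives an at least 8.4-fold lower number from compound 2 to compound 4 (0.92 log units; beyond the scatter) as its step. Compound 2 stands at a limit, not a number: the limit of > 50000 nM in this assay, at which 1 of the 4 values shown sits.

From the compounds shown here alone, what a methoxy group, an amine or a carboxylic acid would do on this phenyl stays open. So does the effect of any change to the ethyl group on the shared core.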